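The compounds below may be only part of what the source reports. "The series", "measured", "known", "first", "only" and "open" are said of these compounds alone.

In a functional assay on MT4 cells (Homo sapiens) for cytotoxicity (on this read-out lower numbers stand for higher toxicity in this test and higher numbers for lower toxicity in this test), compound 1 `CC(C)Sc1nc(O)cc(C(C)c2ccccc2)n1` is reported only as a limit, > 200000 nM. Compound 2 `CC(c1ccccc1)c1cc(O)nc(SC2CCCC2)n1` gives 159000 nM, and compound 3 `CC(c1ccccc1)c1cc(O)nc(SC2CCCCC2)n1` gives 149000 nM. These two stand level, with a 1.1-fold lower number from compound 2 to compound 3 (0.03 log units; within the scatter). Compound 3 therefore sits with compound 2 at the low end of the numbers shown, although that end is not separated from the rest by more than the scatter. The other two measured steps, an at least 1.2-fold lower number from compound 1 to compound 2 (0.09 log units; that floor lies within the scatter) and an at least 1.3-fold lower number from compound 1 to compound 3 (0.12 log units; that floor lies within the scatter), are floors set by the limit, and both lie within the scatter.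

Compound 4 `CC(c1cc(O)nc(SC2CCCCC2)n1)c1c(Cl)cccc1Cl` keeps the cyclohexyl on sulfur but has 2,6-dichlorophenyl in place of phenyl on a saturated chain carbon bound to an aromatic carbon and a saturated chain carbon. All three measured steps change the group on sulfur, so none tests this replacement directly. They show only that the series has so far stayed flat in this assay. An expected step of a 1.4-fold lower number from compound 3 to compound 4 (0.13 log units; within the scatter) is therefore estimated, which means no change beyond the scatter is anticipated, though with real uncertainty. For compound 4 the estimated value is 110000 nM, with an expected range of 35000 nM to 200000 nM.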

Compound 4, half-maximal cytotoxic concentration: > 200000 nM
Compound 4 ended at the assay's limit (the forecaster's own chance of this, stated with the estimate: 25%); middle value at least 1.8-fold (0.25 log units) from the limit.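

In this assay compound 4 is reported only as a limit, > 200000 nM. Putting 2,6-dichlorophenyl in place of phenyl on the saturated chain carbon gives an at least 1.3-fold higher number from compound 3 to compound 4 (0.12 log units; that floor lies within the scatter), so this first change away from the group on sulfur shows that the two added chlorine atoms bring no lower number in this test. How large the step really is cannot be read, and the series now has more than one compound resting on the same ceiling: the limit of > 200000 nM in this assay, at which 2 of the 4 values shown sit.

As far as these compounds go, whether a single chlorine on the phenyl, or two methyl or two methoxy groups in place of the two chlorines, would give a measurable number remains open. Also open, from the compounds shown here alone, is how 2,6-dichlorophenyl behaves with isopropyl or cyclopentyl on sulfur.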